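The compounds below may be only part of what the source reports. "The series", "measured", "known", "first", "only" and "open" are said of these compounds alone.

Compound 3 `Nc1cc(N)c2nc(-c3ccccc3)c(Sc3ccc(Cl)c(Cl)c3)nc2c1` belongs to a small set of related compounds tested in a functional assay on HCT-116 cells (Homo sapiens) for inhibition, read by sulforhodamine B assay, with a stated time of 48 h; a higher number here means that more compound is tolerated, a lower number that less compound is tolerated. In this assay compound 3 gives < 100000 nM, which is a limit of the assay rather than a number. Compound 1 `Nc1cc(N)c2nc(-c3ccccc3)c(Oc3ccc(Cl)c(Cl)c3)nc2c1` in this assay gives < 100000 nM, also a limit. Compound 2 `CCOC(=O)[C@H](CCC(=O)O)NC(=O)c1ccc(Sc2nc3cc(N)cc(N)c3nc2-c2ccccc2)cc1` in this assay gives < 100000 nM, again a limit. Among the compounds with values here, the one step among the measured compounds, a step that the two limits leave unreadable from compound 1 to compound 3, therefore cannot be read for size or direction. Compound 4 `Nc1cc(N)c2nc(-c3ccccc3)c(Sc3ccc(F)cc3)nc2c1` has not yet been tested; it differs from compound 3 by 4-fluorophenyl in place of 3,4-dichlorophenyl on a sulfur. Within the data shown here, no measured step involves this same change, and the only evidence that bears on the question is the limit of < 100000 nM in this assay, at which 3 of the 3 values shown sit, so the numbers alone give no direction and no size for the step. Compound 4 is therefore expected to give 40000 nM, within a range from 8000 nM to 100000 nM. The expected step is estimated as a step that the limit leaves unreadable from compound 3 to compound 4, and it is likely that this assay will once more report only a limit.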

Compound 4, concentration lethal to 50% of the cells: 55000 nM
Estimate against measurement, compound 4: 1.4-fold (0.14 log units) below, and the stated range covers the measured number.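

Compound 4 gives a real number, but the steps to it from compound 1 and compound 3 cannot be read, because those two compounds carry only a limit: the limit of < 100000 nM in this assay, at which 3 of the 4 values shown sit. On these data alone, whether 4-fluorophenyl in place of 3,4-dichlorophenyl on a sulfur changes the read-out at all, and in which direction, stays open.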